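The compounds below may be only part of what the source reports. "The series", "measured", "known", "first", "only" and "open" are said of these compounds alone.

Measured compounds:
Compound 1, `Oc1cc2c(cc1C(c1ccc(F)cc1)N1CCCCC1)OCCO2`: in a functional assay on U-87MG ATCC cells for inhibition, with U-87 MG (Homo sapiens) as the target, read by MTT assay, with a stated time of 72 h (on this read-out lower numbers stand for stronger inhibition and higher numbers for weaker inhibition), compound 1 gives 1000 nM.
Compound 2, `Cc1ccnc(NC(c2ccc([N+](=O)[O-])cc2)c2ccc3cccnc3c2O)c1`: compound 2 gives 3400 nM.
Compound 3, `Oc1c(C(Nc2ccccc2)c2ccccc2)ccc2cccnc12`: compound 3 reaches only a limit, > 10000 nM.

Compound 2 holds the higher of the two numbers given; its nearest neighbour is compound 1, whose number lies lower by a gap beyond the usual scatter. Compound 3 sits at the limit of this assay, as the limit of > 10000 nM in this assay, at which 1 of the 3 values shown sits, shows. Compound 4, `Cc1ccnc(NC(c2ccccc2F)c2ccc3cccnc3c2O)c1`, has not yet been tested. It differs from compound 2 in one place: 2-fluorophenyl in place of 4-nitrophenyl on a saturated chain carbon bound to an aromatic carbon and a nitrogen on an aromatic ring. Going by the values given here, no measured pair shows this change, so compound 4 is expected to move little from compound 2 in this assay, with no step beyond the scatter in either direction. Compound 4 is estimated at 3000 nM, within 1000 nM to 10000 nM, meaning an expected step of a 1.1-fold lower number from compound 2 to compound 4 (0.05 log units; within the scatter).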

Compound 4, half-maximal inhibitory concentration: 13100 nM
The estimate for compound 4 lay 4.4-fold (0.64 log units) below the measured number; the measured number lies above the stated range.
By their numbers in this assay, from the lowest: compound 1; then compound 2; then compound 4.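

On a saturated chain carbon bound to an aromatic carbon and a nitrogen on an aromatic ring, 2-fluorophenyl in place of 4-nitrophenyl gives a 3.9-fold higher number from compound 2 to compound 4 (0.59 log units; beyond the scatter) in this assay. Going by these compounds alone, this is the first pair differing in one place, and it shows that inhibition at this position weakens with this change. Nothing measured here gives a cause for the step.

Going by these compounds, what stays open is whether the step comes from losing 4-nitrophenyl or from gaining 2-fluorophenyl. A 4-methoxyphenyl or 4-cyanophenyl group on the same carbon would help to separate the two.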